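Urea aryl substitution and K562 growth inhibition

The source may report more compounds than this note shows. Statements on the series, on what has been measured and on what is new or still open speak of the compounds shown alone.

Measured compounds:
compound 1, `COc1cc2cc(Oc3ccc(NC(=O)Nc4ccccc4)cc3)c(C)nc2cc1OC`: 42.8%
compound 2, `COc1cc2cc(Oc3ccc(NC(=O)Nc4ccc(Cl)c(C(F)(F)F)c4)cc3)c(C)nc2cc1OC`: -9.54%

In a functional assay on K562 cells (Homo sapiens) for inhibition, read by sulforhodamine B assay, with a stated time of 48 h, tested at 10 uM (a higher number here means a weaker effect of the compound at the concentration tested, a lower number a stronger effect), compound 1 gives 42.8%, and compound 2 gives -9.54%. Among the measured compounds shown here, compound 2 stands lowest of the two numbers; compound 1 is its only neighbour, and the one measured step, a number 52.3 percentage points lower from compound 1 to compound 2 (beyond the scatter), is large and beyond the scatter, arising from 4-chloro-3-(trifluoromethyl)phenyl in place of phenyl on an amide-type nitrogen.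

Compound 3, `COc1cc2cc(Oc3ccc(NC(=O)Nc4ccc(Cl)c(Cl)c4)cc3)c(C)nc2cc1OC`, differs from compound 2 by chloro in place of trifluoromethyl on an aromatic carbon. For the measured compounds named here, no measured step isolates this exchange: the step from compound 1 to compound 2 introduced the chloro and the trifluoromethyl together, so it speaks only to the substituted ring as a whole. Compound 3 keeps the chloro already present and exchanges the trifluoromethyl for chloro, so a step no larger than the scatter is expected, a number 11.5 percentage points higher from compound 2 to compound 3 (beyond the scatter). Compound 3 is therefore estimated at 2%, within a range from -14% to 26%.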

Compound 3, a percentage reported as activity, at one concentration (the size of the read-out at that concentration, not a potency): 12.7%
Estimate against measurement, compound 3: 10.7 percentage points below, within the range that was stated.
By their numbers in this assay, from the lowest: compound 2; then compound 3; then compound 1.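

Among the compounds shown here, exchanging trifluoromethyl for chloro on this aromatic carbon is the first change isolated at this position, and in this assay it gives a number 22.2 percentage points higher from compound 2 to compound 3 (beyond the scatter), so the two groups are not interchangeable here, as the earlier step, which introduced both substituents together, could not show. Even so, the ring bearing only chloro groups stands apart from the unsubstituted phenyl, with a number 30.1 percentage points lower from compound 1 to compound 3 (beyond the scatter), so the trifluoromethyl is not required for a step beyond the scatter from compound 1. No measurement here accounts for the difference between the two groups.

The compounds shown leave open how much each substituent contributes alone, since no ring carries only the chloro or only the trifluoromethyl. They also leave open how a methyl, a nitrile or an amine would behave on this aromatic carbon.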